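This account rests on a few compounds, and the source may have more. Where it says the series, first, only, none or still open, it means among the compounds named here.

In a functional assay on MCF7 cells (Homo sapiens) for cytotoxicity, read by MTT assay, with a stated time of 24 h (on this read-out lower numbers stand for stronger inhibition and higher numbers for weaker inhibition), compound 1 (`CCNc1cc(-c2ccc(NC(=O)Nc3ccc(C(F)(F)F)cc3)cc2C(F)(F)F)ccn1`) gives 2390 nM. Going by the values given here, compound 2 (`CCCNc1cc(-c2ccc(NC(=O)Nc3cccc(Cl)c3)cc2C(F)(F)F)ccn1`) gives 8230 nM, the higher of the two numbers so far, and its gap to compound 1 lies beyond the scatter. Compound 3 (`CCCNc1cc(-c2ccc(NC(=O)Nc3ccc(C(F)(F)F)cc3)cc2C(F)(F)F)ccn1`) remains unmeasured. Going from compound 2 to compound 3, the change is 4-(trifluoromethyl)phenyl in place of 3-chlorophenyl on an amide-type nitrogen. Among the compounds with values here, no measured pair isolates this change, so the evidence is indirect. Compound 1 also carries the 4-(trifluoromethyl)phenyl and gives 2390 nM, but it differs from compound 2 in more than one place. A moderate step towards a lower number is therefore expected in this assay, estimated as a 2.4-fold lower number from compound 2 to compound 3 (0.37 log units; beyond the scatter). The expected value for compound 3 is 3500 nM, with an estimated range of 1500 nM to 8000 nM.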

Compound 3, half-maximal inhibitory concentration: 7680 nM
Compound 3: middle estimate off by 2.2-fold (0.34 log units), on the low side; low and high end bracket the measured number.
By their numbers in this assay, from the lowest: compound 1; then compounds 3 and 2 (each within the scatter of the next).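

In this assay, 4-(trifluoromethyl)phenyl in place of 3-chlorophenyl on an amide-type nitrogen gives a 1.1-fold lower number from compound 2 to compound 3 (0.03 log units; within the scatter) and so has no readable effect in this pair. Going by these compounds alone, the only step beyond the scatter is a different change, methyl in place of hydrogen on a saturated chain carbon, two bonds along the chain from a nitrogen on an aromatic ring, which gives a 3.2-fold higher number from compound 1 to compound 3 (0.51 log units; beyond the scatter) and is a modest loss on this read-out. No measurement at hand bears on the cause of either step.

Each change rests on a single pair, so neither reading can be carried to other compounds in the series. As far as these compounds go, it remains open whether a butyl chain on the nitrogen on the aromatic ring extends the step, and whether a 4-methoxyphenyl group on the amide-type nitrogen departs from compound 3.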